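Chloropyrimidine swap on the amine nitrogen of compound 3

The source may report more compounds than this note shows. Statements on the series, on what has been measured and on what is new or still open speak of the compounds shown alone.

Measured in a functional assay on CWR22R cells (Homo sapiens) for antiproliferative activity, read by CCK-8 assay, with a stated time of 6 days; on this read-out lower numbers stand for stronger inhibition and higher numbers for weaker inhibition:
- compound 1 `C[C@@H](Cn1ccc(-c2ccc(C#N)c(Cl)c2)n1)NC(=O)c1ccccc1F`: "not determined" (no result reported)
- compound 2 `C[C@@H](Cn1ccc(-c2ccc(C#N)c(Cl)c2)n1)NC(=O)C1CC(=O)C1`: "not determined" (no result reported)
- compound 3 `C[C@@H](Cn1ccc(-c2ccc(C#N)c(Cl)c2)n1)Nc1cncnc1`: > 30000 nM (a limit of the assay, not a number)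

Going by the values given here, compound 3 is the only compound with a reading, and that reading is a limit rather than a number. The evidence amounts to one entry: the limit of > 30000 nM in this assay, at which 1 of the 3 values shown sits. Among the compounds with values here, compound 1 and compound 2 have no result, so no measured step is available to calibrate a structural change, and compound 3 offers only a lower bound on its true value.

The next compound is compound 4 `C[C@@H](Cn1ccc(-c2ccc(C#N)c(Cl)c2)n1)Nc1nccc(Cl)n1`. It keeps the core of compound 3 and changes one group: 4-chloropyrimidin-2-yl in place of pyrimidin-5-yl on an amine nitrogen. With compound 3 sitting at > 30000 nM, the only direction open to a numerical result is toward stronger inhibition, so any expectation here is loose. The expected step is an at least 2.5-fold lower number from compound 3 to compound 4 (0.39 log units; beyond the scatter), and this estimate is modest in size and uncertain. A second reading that gives only a limit is also quite possible.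

For compound 4 the estimated value in this assay is 12000 nM, with an expected range from 2000 nM to 30000 nM.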

Compound 4, half-maximal inhibitory concentration: > 30000 nM
Compound 4: no number, only a limit (the forecaster's own chance of this, stated with the estimate: 45%); middle value at least 2.5-fold (0.39 log units) from the limit.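

Compound 4 gives > 30000 nM as a limit of the assay, not a number. Going by these compounds alone, compound 3 also stands at a limit, so no step between compound 3 and compound 4 can be read. The compounds shown leave open whether any group on the amine nitrogen of the shared core gives a numerical antiproliferative reading.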